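Swapping benzoyl for tert-butoxycarbonyl on a thiophene amide

This account rests on a few compounds, and the source may have more. Where it says the series, first, only, none or still open, it means among the compounds named here.

Of the compounds shown here, two have been tested so far for how strongly they harm a mouse macrophage cell line. Compound 1, with the structure `Cc1ccc(C)c(N2C(=N)S/C(=C\c3ccc(OCc4ccccc4)cc3)C2=O)c1`, was tested in an ADME assay on RAW264.7 cells (Mus musculus) for cytotoxicity, read by MTT assay, with a stated time of 48 h, tested at 50 uM (on this read-out higher numbers stand for more inhibition at the one concentration tested (going by the name of the read-out) and lower numbers for less inhibition), where compound 1 gives 45.8%. Compound 2, with the structure `NC(=O)c1c(NC(=O)c2ccc(Cl)cc2)sc2c1CCN(C(=O)c1ccccc1)C2`, was run in this assay as well, and compound 2 gives 42.5%. Of the two numbers, that of compound 2 is the lower, yet the gap to compound 1 lies within the scatter of this kind of measurement, so the two readings cannot be told apart.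

The next compound, compound 3, has the structure `CC(C)(C)OC(=O)N1CCc2c(sc(NC(=O)c3ccc(Cl)cc3)c2C(N)=O)C1`. Its difference from compound 2 is a single change: tert-butoxy in place of phenyl on a carbonyl carbon. Within the data shown here, no measured pair differs in just this way, so nothing shows how such a change has behaved in this assay before.

Among the measured compounds shown here, with only two close values to go on, the step from compound 2 to compound 3 is expected to be small and, if anything, downward, roughly a number 4.5 percentage points lower from compound 2 to compound 3 (within the scatter). Compound 3 is therefore estimated to give 38% in this assay, with a likely range from 22% to 54%.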

Compound 3, a percentage reported as inhibition, at one concentration (the size of the read-out at that concentration, not a potency): 37.3%
For compound 3 the middle estimate is 0.7 percentage points above the measured one, within the range that was stated.
By their numbers in this assay, from the lowest: compounds 3, 2 and 1 (each within the scatter of the next).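

Among these compounds, replacing benzoyl with tert-butoxycarbonyl gives the first comparison of two compounds that differ in one place in this assay and the step is a number 5.2 percentage points lower from compound 2 to compound 3 (within the scatter) so it cannot be told apart from repeat-to-repeat variation. At this position, on a carbonyl carbon attached to an amide-type nitrogen in a ring, phenyl, with its six-membered aromatic ring of carbon only, and tert-butoxy, with no ring and one hydrogen-bond acceptor, therefore give readings that this measurement does not separate. No measurement available here accounts for this similarity. 

On these data alone, it remains open whether a different group on the same carbonyl carbon, such as a methyl group or an amine that would turn the carbonyl into a urea, would give a reading clearly apart from these two in this assay or would also fall within the usual scatter. Also open, as far as these compounds go, is what happens if the whole carbonyl unit is removed to leave a hydrogen on the ring nitrogen, and whether this swap would give a similar result on a different core.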